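Swapping the ether substituent toward a simple chlorinated benzyl

The source may report more compounds than this note shows. Statements on the series, on what has been measured and on what is new or still open speak of the compounds shown alone.

Measured compounds:
- compound 1 `C#CCOc1ccc2c(=O)c(-c3cc(OC)c(OC)cc3OC)coc2c1`: 4950 nM
- compound 2 `COc1cc(OC)c(-c2coc3cc(OCC(=O)c4cccc(C(F)(F)F)c4)ccc3c2=O)cc1OC`: > 10000 nM
- compound 3 `COc1cc(OC)c(-c2coc3cc(OCc4ccccc4C(F)(F)F)ccc3c2=O)cc1OC`: 6550 nM

Three compounds sharing one core were tested in a functional assay on HepG2 cells (Homo sapiens) for antiproliferative activity, read by MTT assay, with a stated time of 24 h; on this read-out lower numbers stand for stronger inhibition and higher numbers for weaker inhibition. Compound 1 `C#CCOc1ccc2c(=O)c(-c3cc(OC)c(OC)cc3OC)coc2c1` gives 4950 nM in this assay. Compound 3 `COc1cc(OC)c(-c2coc3cc(OCc4ccccc4C(F)(F)F)ccc3c2=O)cc1OC` gives 6550 nM. For the measured compounds named here, for compound 2 `COc1cc(OC)c(-c2coc3cc(OCC(=O)c4cccc(C(F)(F)F)c4)ccc3c2=O)cc1OC` the result is only a limit of the assay, > 10000 nM, so its true value is not known as a number; this is the one compound sitting at the limit of > 10000 nM in this assay, at which 1 of the 3 values shown sits.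

Compound 4 `COc1cc(OC)c(-c2coc3cc(OCc4ccc(Cl)cc4)ccc3c2=O)cc1OC` is not yet measured. It differs from compound 2 by 4-chlorophenyl in place of (3-(trifluoromethyl)phenyl)carbonyl on a saturated chain carbon bound to an oxygen on an aromatic ring. Going by the values given here, the step that bears most directly on this change is the one from compound 2 to compound 3, which replaced the same group by a different benzyl-type substituent and gave an at least 1.5-fold lower number from compound 2 to compound 3 (0.18 log units; that floor lies within the scatter). The step from compound 1 to compound 3 was a 1.3-fold higher number from compound 1 to compound 3 (0.12 log units; within the scatter), so the benzyl-type ethers cluster together within the scatter.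

Because compound 3 sits at 6550 nM, compound 4 is expected to land near that value. The estimate for compound 4 is 6000 nM, with a range from 2500 nM to 15000 nM, which means an expected step of an at least 1.6-fold lower number from compound 2 to compound 4 (0.22 log units; that floor lies within the scatter).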

Compound 4, half-maximal inhibitory concentration: 940 nM
Estimate against measurement, compound 4: 6.4-fold (0.81 log units) above; measured number outside the range, below it.
By their numbers in this assay, from the lowest: compound 4; then compounds 1 and 3 (each within the scatter of the next). At a limit, above all of these: compound 2.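

In this assay, 4-chlorophenyl on the saturated chain carbon bound to an oxygen on an aromatic ring stands apart from the other substituents shown, with a 7.0-fold lower number from compound 3 to compound 4 (0.84 log units; beyond the scatter) and a 5.3-fold lower number from compound 1 to compound 4 (0.72 log units; beyond the scatter). Compound 3 also carries a substituted phenyl ring at this place, yet it stays within the scatter of compound 1, so a ring alone does not account for the result; what the ring carries matters, while an at least 10-fold lower number from compound 2 to compound 4 (1.02 log units; beyond the scatter) can be read only as a floor. Compound 2 itself is a limit of the assay and not a number: the limit of > 10000 nM in this assay, at which 1 of the 4 values shown sits.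

The compounds shown leave open whether the result depends on the chlorine or on where it stands on the ring, since 4-chlorophenyl and 2-(trifluoromethyl)phenyl differ in both, and a 2-chlorophenyl or 4-(trifluoromethyl)phenyl group would be needed to separate the two. On these data alone, it also remains open whether 4-fluorophenyl, 4-bromophenyl or 4-methoxyphenyl at this place would give a number like that of compound 4 or one nearer to those of compound 1 and compound 3.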